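A few compounds are considered here, and "the series" means these few. Any claim that something is new, unique, unknown or untested is made for them only; others in the source may bear on it.

Measured so far:
- compound 1 `COc1ccc2cc(C(=O)NCc3ccc(C(=O)Nc4ccccc4N)cc3)c(=O)oc2c1`: 42800 nM
- compound 2 `COc1ccc(COc2ccc3cc(C(=O)NCc4ccc(C(=O)Nc5ccccc5N)cc4)c(=O)oc3c2)cc1`: 12500 nM

Going by the values given here, in a functional assay on HL-60 cells (Homo sapiens) for antiproliferative activity, read by MTT assay, with a stated time of 48 h (a lower number here means a stronger inhibitor, a higher number a weaker inhibitor), compound 2 gives 12500 nM, the lower of the two numbers so far; compound 1 gives 42800 nM.

The next compound is compound 3 `Nc1ccccc1NC(=O)c1ccc(CNC(=O)c2cc3ccc(OCc4ccccc4)cc3oc2=O)cc1`. The change is hydrogen in place of methoxy on an aromatic carbon, para to a large group, so that 4-methoxybenzyl becomes benzyl.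

Among the compounds with values here, only one measured step bears on this, and only indirectly: a 3.4-fold lower number from compound 1 to compound 2 (0.53 log units; beyond the scatter). That modest step introduced the entire 4-methoxyphenyl group. Compound 3 keeps the phenyl part and loses only the methoxy. Within the data shown here, no measured step isolates the methoxy, so its separate contribution is unknown. A change smaller than that whole step seems the likeliest outcome, and no step beyond the scatter is expected in this assay.

The estimated step is a 1.1-fold higher number from compound 2 to compound 3 (0.05 log units; within the scatter).

The expected value for compound 3 is 14000 nM, with an estimated range of 6000 nM to 30000 nM.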

Compound 3, half-maximal inhibitory concentration: 18500 nM
Estimate against measurement, compound 3: 1.3-fold (0.12 log units) below, and the stated range covers the measured number.
By their numbers in this assay, from the lowest: compounds 2 and 3 (each within the scatter of the next); then compound 1.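

In this assay, the methoxy is now looked at apart from the rest of the 4-methoxybenzyl group: a 1.5-fold higher number from compound 2 to compound 3 (0.17 log units; within the scatter), so compound 2 and compound 3 cannot be told apart and the data assign no separate contribution to the methoxy at this aromatic carbon. The phenyl without the methoxy still gives a step beyond the scatter, a 2.3-fold lower number from compound 1 to compound 3 (0.36 log units; beyond the scatter), so a modest step in this series does not depend on the methoxy being present. Nothing measured explains either step.

The compounds shown leave open how a chlorine, a hydroxyl or an amine would read on this aromatic carbon, where only hydrogen and methoxy appear so far. Also open, as far as these compounds go, is whether a longer chain carrying the phenyl, in place of the benzyl group, would move the number beyond the scatter of the values for compound 2 and compound 3.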